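Sigma-1 binding: amide replaces benzyl on the ring nitrogen

The source may hold more compounds than are shown below. What is called first, only, known or untested is meant among the compounds shown, and "the series" means these compounds.

Compound 3 `Fc1ccc(C(SCCNC2CCN(Cc3cc4ccccc4o3)CC2)c2ccc(F)cc2)cc1` gives 205 nM in an assay on membranes from Cortex for displacement of a labelled ligand from Sigma non-opioid intracellular receptor 1 (Cavia porcellus), read by scintillation counting, with a stated time of 120 min; a lower number here means a stronger inhibitor, a higher number a weaker inhibitor. Compound 2 `Fc1ccc(C(SCCNC2CCN(Cc3cc4ccccc4[nH]3)CC2)c2ccc(F)cc2)cc1` gives 205 nM, and no change at the digits printed from compound 2 to compound 3 (within the scatter). Compound 1 `Fc1ccc(C(SCCNC2CCN(Cc3ccc(Cl)cc3)CC2)c2ccc(F)cc2)cc1` gives 45.5 nM; a 4.5-fold higher number from compound 1 to compound 3 (0.65 log units; beyond the scatter) and a 4.5-fold higher number from compound 1 to compound 2 (0.65 log units; beyond the scatter), so compound 3 and compound 2 share the highest number of the three.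

Compound 4 `O=C(c1ccccc1F)N1CCC(NCCSC(c2ccc(F)cc2)c2ccc(F)cc2)CC1` carries the change ((2-fluorophenyl)carbonyl in place of (1-benzofuran-2-yl)methyl on an amine nitrogen in a ring). For the measured compounds named here, none of the measured steps touches this position: a 4.5-fold higher number from compound 1 to compound 2 (0.65 log units; beyond the scatter) and a 4.5-fold higher number from compound 1 to compound 3 (0.65 log units; beyond the scatter) exchange the aryl group on the saturated chain carbon bound to the ring nitrogen, and that exchange alone moves the number by a modest amount. Going by the values given here, replacing the whole (1-benzofuran-2-yl)methyl group by a (2-fluorophenyl)carbonyl group on the ring nitrogen has no direct precedent here, so the step is expected to be larger than the measured ones and in the direction of a higher number.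

Compound 4 is therefore estimated at 500 nM, within 120 nM to 2500 nM, which is expected to be a 2.4-fold higher number from compound 3 to compound 4 (0.39 log units; beyond the scatter).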

Compound 4, inhibition constant: 3.57 nM
Compound 4: middle estimate off by 140-fold (2.15 log units), on the high side; measured number outside the range, below it.
By their numbers in this assay, from the lowest: compound 4; then compound 1; then compounds 2 and 3 (each within the scatter of the next).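

In this assay, the group on the amine nitrogen in a ring has a far larger effect than the aryl exchanges seen so far: a 57-fold lower number from compound 3 to compound 4 (1.76 log units; beyond the scatter), a 57-fold lower number from compound 2 to compound 4 (1.76 log units; beyond the scatter) and a 13-fold lower number from compound 1 to compound 4 (1.11 log units; beyond the scatter) all run towards a lower number and all are large. Compound 4 is therefore the strongest inhibitor of the four, and a carbonyl can take the place of the saturated chain carbon on that nitrogen without loss of affinity. No measurement here accounts for the size of these steps.

Each step changes the linking carbon and the aryl group together, so the share of the carbonyl and that of the 2-fluorophenyl group remain unresolved. A 2-fluorobenzyl group, an unsubstituted benzoyl group or a 1-benzofuran-2-ylcarbonyl group on the same nitrogen would separate the two.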